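Swapping the aryl group on the sulfonyl sulfur

The source may hold more compounds than are shown below. What is called first, only, known or untested is meant among the compounds shown, and "the series" means these compounds.

Three measured compounds share one core and were tested in an assay on isolated protein for displacement of a labelled ligand from metabotropic glutamate receptor 5 (Homo sapiens), with a stated time of 60 min, tested at 1 uM; a higher number here means more inhibition at the concentration tested (going by the name of the read-out), a lower number less inhibition. Compound 1 `CC1CCN(c2c(S(=O)(=O)c3cccc(Cl)c3)cnc3cc(Cl)ccc23)CC1` gives 92%. Compound 3 `CC1CCN(c2c(S(=O)(=O)c3cccc(Cl)c3)cnc3ccc(F)cc23)CC1` gives 92%, level with compound 1 at the digits shown, and these two stand together as the highest of the three numbers. Compound 2 `Cc1cc(C)cc(S(=O)(=O)c2cnc3ccc(F)cc3c2N2CCC(C)CC2)c1` gives 83%; the step of a number 9 percentage points higher from compound 2 to compound 3 (within the scatter) shows that exchanging the aryl group on the sulfonyl sulfur left the read-out within the scatter.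

Compound 4 `CC1CCN(c2c(S(=O)(=O)c3ccc(C#N)cc3)cnc3cc(Cl)ccc23)CC1` has not yet been measured. It differs from compound 1 in one place: 4-cyanophenyl in place of 3-chlorophenyl on a sulfonyl sulfur. Among the compounds with values here, the only measured step that touches the aryl group on the sulfonyl sulfur is the one from compound 2 to compound 3, and it stayed within the scatter. Within the data shown here, no measured compound carries a 4-cyanophenyl group, so the evidence for this particular exchange is thin. A step of about a number 7 percentage points lower from compound 1 to compound 4 (within the scatter) is therefore expected, that is, none beyond the scatter. Compound 4 is expected to give 85%, with a range from 65% to 98%.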

Compound 4, a percentage reported as inhibition, at one concentration (the size of the read-out at that concentration, not a potency): 70%
For compound 4 the middle estimate is 15 percentage points above the measured one; low and high end bracket the measured number.
By their numbers in this assay, from the lowest: compound 4; then compounds 2, 1 and 3 (each within the scatter of the next).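

Within the data shown here, the step of a number 22 percentage points lower from compound 1 to compound 4 (beyond the scatter) is the only one at the aryl group on the sulfonyl sulfur that lies beyond the scatter in this assay. The other exchange here, a number 9 percentage points higher from compound 2 to compound 3 (within the scatter), stayed within the scatter, so this place accepts the 3-chlorophenyl and 3,5-dimethylphenyl groups but not every aryl group. No measurement here explains the drop, and this single step cannot separate the arrival of the nitrile from the departure of the chlorine.

The compounds shown leave open whether a 3-cyanophenyl or 4-chlorophenyl group would stay close to compound 1 or fall towards compound 4. They also leave open what an unsubstituted phenyl or a 4-methoxyphenyl group would give at this place.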